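This account rests on a few compounds, and the source may have more. Where it says the series, first, only, none or still open, it means among the compounds named here.

Measured in a functional assay on HepG2 cells (Homo sapiens) for antiproliferative activity, read by CCK-8 assay, with a stated time of 48 h; a higher number here means a weaker inhibitor, a lower number a stronger inhibitor:
Compound 1 `O=C(CCCCCCOc1ccc(-c2nnc(-c3ccccc3)s2)cc1)NO`: > 50000 nM, a limit of the assay and not a number.
Compound 2 `O=C(CCCCOc1cccc(-c2nnc(-c3ccccc3)s2)c1)NO`: 11000 nM.
Compound 3 `O=C(CCCCCOc1cccc(-c2nnc(-c3ccccc3)s2)c1)NO`: 1400 nM.

Compound 3 holds the lower of the two actual numbers in this assay, and compound 2 stands above it. Compound 1 gives only a limit. Compound 4 `O=C(CCCCCCOc1cccc(-c2nnc(-c3ccccc3)s2)c1)NO` follows from compound 3 through a single change, (hydroxycarbamoyl)methyl in place of hydroxycarbamoyl on a saturated chain carbon, five bonds along the chain from an oxygen on an aromatic ring.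

Going by the values given here, the one measured step of the same kind is a 7.9-fold lower number from compound 2 to compound 3 (0.90 log units; beyond the scatter), made four bonds along the chain from that oxygen. It was modest but beyond the scatter. A single step does not make a trend, and a second one need not match it. The expectation is a smaller move in the same direction, towards a lower number, and the expected step is a 2.3-fold lower number from compound 3 to compound 4 (0.37 log units; beyond the scatter). For compound 4 the estimated value is 600 nM, with an expected range from 150 nM to 2500 nM.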

Compound 4, half-maximal inhibitory concentration: 2200 nM
The estimate for compound 4 lay 3.7-fold (0.56 log units) below the measured number; measured number inside the range.
By their numbers in this assay, from the lowest: compounds 3 and 4 (each within the scatter of the next); then compound 2. At a limit, above all of these: compound 1.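

Adding one more chain carbon at this position gives no readable change in this assay: a 1.6-fold higher number from compound 3 to compound 4 (0.20 log units; within the scatter). The earlier extension, one bond closer to the oxygen on the aromatic ring, had moved the number beyond the scatter, so this change does not act evenly along the chain, and compounds 3 and 4 stand level. Measured across the whole extension, with 2-(hydroxycarbamoyl)ethyl in place of hydroxycarbamoyl, the gain made at the first step remains: a 5.0-fold lower number from compound 2 to compound 4 (0.70 log units; beyond the scatter).

From the compounds shown here alone, whether a longer chain, or a carboxylic acid in place of the hydroxycarbamoyl end, would stay at this level remains open. Compound 1 gives only a limit of the assay and not a number, so its comparison with compound 4 cannot be read: the limit of > 50000 nM in this assay, at which 1 of the 4 values shown sits.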